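The source may report more compounds than this note shows. Statements on the series, on what has been measured and on what is new or still open speak of the compounds shown alone.

Measured compounds:
compound 1 `CCOc1cc(NC(=O)C2(NC(=O)c3ccc4c(C5CCCC5)c(-c5ncc(Cl)cn5)n(C)c4c3)CCC2)ccc1/C=C/C(=O)OCCOCCOC`: 4600 nM
compound 2 `CCOc1cc(NC(=O)C2(NC(=O)c3ccc4c(C5CCCC5)c(-c5ncc(Cl)cn5)n(C)c4c3)CCC2)ccc1/C=C/C(=O)OCC(N)=O`: 4400 nM

In an ADME assay on the whole organism (plasma) for pharmacokinetics, with Rattus norvegicus as the target, at a dose of 10 mg/kg by the oral route (on this read-out higher numbers stand for higher exposure at the dose given and lower numbers for lower exposure), compound 1 gives 4600 nM and compound 2 gives 4400 nM. On the numbers shown compound 2 and compound 1 cannot be told apart, since a 1.0-fold lower number from compound 1 to compound 2 (0.02 log units; within the scatter) lies within the scatter. Compound 3 `CCOc1cc(NC(=O)C2(NC(=O)c3ccc4c(C5CCCC5)c(-c5ncc(Cl)cn5)n(C)c4c3)CCC2)ccc1/C=C/C(=O)OCC(=O)N1CCOCC1` has not yet been measured in this assay. It differs from compound 2 by morpholin-4-yl in place of amino on a carbonyl carbon. Among the compounds with values here, the only measured step that bears on this region, a 1.0-fold lower number from compound 1 to compound 2 (0.02 log units; within the scatter), also altered the group on the saturated chain carbon bound to an oxygen next to a carbonyl group, and it left the exposure essentially unchanged. On that single precedent the expected step of no change at the digits printed from compound 2 to compound 3 (within the scatter) in this assay is none beyond the scatter. Compound 3 is therefore estimated at 4400 nM, with a range of 2200 nM to 8800 nM.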

Compound 3, maximal plasma concentration: 4000 nM
Estimate against measurement, compound 3: 1.1-fold (0.04 log units) above; the range from low to high includes it.
By their numbers in this assay, from the lowest: compounds 3, 2 and 1 (each within the scatter of the next).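

In this assay, morpholin-4-yl in place of amino on a carbonyl carbon gives a 1.1-fold lower number from compound 2 to compound 3 (0.04 log units; within the scatter), so a six-membered non-aromatic ring can enter here and the hydrogen-bond donor of the amino group can leave without a readable shift. The wider swap of (morpholin-4-yl)carbonyl in place of (2-methoxyethoxy)methyl on the saturated chain carbon gives a 1.2-fold lower number from compound 1 to compound 3 (0.06 log units; within the scatter), which means that all three groups shown at this carbon remain inseparable on this read-out. No available measurement accounts for this flat response.

Going by these compounds, it remains open whether a carboxylic acid at this carbon, or a piperazine in place of the morpholine, would move the maximal plasma concentration beyond the scatter. A peak value at a single oral dose also leaves the rest of the plasma time course undefined.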